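Aryl amine exchange on the shared core, single-point inhibition

This account rests on a few compounds, and the source may have more. Where it says the series, first, only, none or still open, it means among the compounds named here.

The series rests on one shared core, carried by compound 1 `Cc1n[nH]c2ccc(-c3nc4cnc(N5CCN(C)CC5)cn4c3Nc3ccccc3F)cc12` and compound 2 `Cc1n[nH]c2ccc(-c3nc4cnc(N5CCN(C)CC5)cn4c3Nc3ccccc3)cc12`. In a functional assay on MV4-11 cells (Homo sapiens) for inhibition, with a stated time of 120 h, tested at 10 uM (a higher number here means more inhibition at the concentration tested (going by the name of the read-out), a lower number less inhibition), compound 1 gives 0%, and compound 2 gives 0%. The only measured step, no change at the digits printed from compound 1 to compound 2 (within the scatter), shows no movement, so compound 1 stands level with compound 2 at the digits shown and nothing in the pair sets one apart from the other.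

Compound 3 `COc1ccc(Nc2c(-c3ccc4[nH]nc(C)c4c3)nc3cnc(N4CCN(C)CC4)cn23)cc1OC` awaits measurement. It differs from compound 1 in one place: 3,4-dimethoxyphenyl in place of 2-fluorophenyl on a nitrogen on an aromatic ring. The measured step of no change at the digits printed from compound 1 to compound 2 (within the scatter) concerns a different exchange on the nitrogen on an aromatic ring and shows no change within the scatter. Among the measured compounds shown here, no step in hand touches 3,4-dimethoxyphenyl entering, so the data give no ground for movement in either direction. The expected step from compound 1 to compound 3 is therefore a number 2 percentage points higher from compound 1 to compound 3 (within the scatter), none beyond the scatter. For compound 3 the estimate in this assay is 2%, with a range from -10% to 20%, resting on the absence of any response in the measured pair.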

Compound 3, a percentage reported as inhibition, at one concentration (the size of the read-out at that concentration, not a potency): 6.27%
Estimate against measurement, compound 3: 4.3 percentage points below, and the stated range covers the measured number.
By their numbers in this assay, from the lowest: compounds 1, 2 and 3 (each within the scatter of the next).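

In this assay the 3,4-dimethoxyphenyl group on a nitrogen on an aromatic ring gives a number 6.3 percentage points higher from compound 1 to compound 3 (within the scatter) against 2-fluorophenyl and a number 6.3 percentage points higher from compound 2 to compound 3 (within the scatter) against phenyl. The earlier pair tested only the exchange of fluoro for hydrogen, whereas this exchange replaces 2-fluorophenyl, with 7 heavy atoms and 0 hydrogen-bond acceptors, by a group with 10 heavy atoms and 2 hydrogen-bond acceptors, and the read-out at this position still stays within the scatter across all three compounds. No measurement in hand offers an explanation for this flat result.

Still open, as far as these compounds go, is whether any group on this nitrogen can move the read-out beyond the scatter, for example a phenyl ring carrying a dimethylamino group or a carboxylic acid, or a saturated ring such as cyclohexyl in place of the aromatic ring. Also open, from the compounds shown here alone, is whether an exchange elsewhere on the shared core, such as a morpholine in place of the methylpiperazine, would move the read-out in this assay format at the single concentration used.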